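Swapping the Acyl Group on a Sulfonamide Nitrogen

A few compounds are considered here, and "the series" means these few. Any claim that something is new, unique, unknown or untested is made for them only; others in the source may bear on it.

Compound 1 `O=C(NS(=O)(=O)c1ccc(NC(=O)c2ccc(Cl)cc2Cl)cc1)c1ccccc1` carries a benzoyl group on its sulfonamide nitrogen. In a functional assay on HEK293 cells for agonist activity at probable G-protein coupled receptor 27 (Homo sapiens), read by a luciferase reporter and beta-arrestin recruitment, with a stated time of 10 min (a lower number here means a smaller maximal response, a higher number a larger maximal response), compound 1 is recorded as "not determined" (no result reported), so there is no number to place it against the others. Two related compounds with a plain phenyl on the sulfonamide nitrogen have been measured: compound 2 `O=C(Nc1ccc(S(=O)(=O)Nc2ccccc2)cc1)c1ccc(Br)cc1F` gives 67% in this assay, and compound 3 `N#Cc1ccc(C(=O)Nc2ccc(S(=O)(=O)Nc3ccccc3)cc2)c(F)c1` gives 29%. Within the data shown here, the one step that joins them, a number 38 percentage points lower from compound 2 to compound 3 (beyond the scatter), changes only a substituent on the benzamide ring.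

Compound 4 `O=C(Nc1ccc(S(=O)(=O)Nc2ccccc2Cl)cc1)c1ccc(Cl)cc1Cl` is compound 1 with the change (2-chlorophenyl in place of benzoyl on a sulfonamide nitrogen). Among the measured compounds shown here, no measured pair shows this particular change, so the step from compound 2 to compound 3 does not bear on it directly; it only shows that the shared core can give either a large or a small maximal response in this assay. Compound 4 resembles compound 2 in carrying a halogenated benzamide, which is the nearest measured point of reference.

Compound 4 is therefore expected to give about 55% in this assay. Allowing for the wide spread seen across the measured compounds, the maximal response of compound 4 is estimated to fall between 20% and 90%.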

Compound 4, largest response reached (Emax), in percent of the reference or control that the assay uses: 53%
Compound 4: middle estimate off by 2 percentage points, on the high side, and the stated range covers the measured number.
By their numbers in this assay, from the lowest: compound 3; then compound 4; then compound 2.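

No new step can be read here: compound 1 has no number in this assay, and compound 4 differs from compound 2 and compound 3 in more than one place. The compounds shown leave open how 2-chlorophenyl in place of benzoyl on a sulfonamide nitrogen changes the maximal response. Nothing here offers an explanation for the result of compound 4.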